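Trimming the Amide: From Compound 3 to Compound 4

The compounds below may be only part of what the source reports. "The series", "measured", "known", "first", "only" and "open" are said of these compounds alone.

Of the compounds shown here, three sharing one core have been tested in a functional assay on the whole organism with Rattus norvegicus as the target, at a dose of 40 mg/kg by the intraperitoneal route; a lower number here means less inhibition, a higher number more inhibition at the dose given (going by the name of the read-out). Compound 1 `COC(=O)Nc1c(C)nc2c(OCc3ccccc3)cccn12` gives 0%, compound 2 `Cc1nc2c(OCc3ccccc3)cccn2c1/N=C/N(C)C` gives 64%, and compound 3 `CNC(=O)Nc1c(C)nc2c(OCc3ccccc3)cccn12` gives 22%. Compound 3 stands second highest of the three, above compound 1 and well below compound 2. Compound 4 `CNc1c(C)nc2c(OCc3ccccc3)cccn12` differs from compound 3 by methyl in place of methylcarbamoyl on a nitrogen on an aromatic ring. For the measured compounds named here, no measured step matches this change. The nearest are a number 22 percentage points higher from compound 1 to compound 3 (beyond the scatter) and a number 42 percentage points lower from compound 2 to compound 3 (beyond the scatter), which show that the group on the nitrogen on the aromatic ring shifts the read-out strongly, upward or downward. The expectation for compound 4 is therefore uncertain, and a step of a number 8 percentage points higher from compound 3 to compound 4 (within the scatter) is estimated. Compound 4 is expected to give 30%, between 0% and 65%.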

Compound 4, a percentage reported as inhibition, in the whole organism at one dose (the size of the read-out at that dose, not a potency): 55%
Compound 4: middle estimate off by 25 percentage points, on the low side; the measured number falls inside the stated range.
By their numbers in this assay, from the lowest: compound 1; then compound 3; then compounds 4 and 2 (each within the scatter of the next).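

In this assay, the read-out at this nitrogen on an aromatic ring rises once the carbonyl-bearing groups give way to methyl, with methyl replacing methylcarbamoyl giving a number 33 percentage points higher from compound 3 to compound 4 (beyond the scatter) and methyl replacing methoxycarbonyl giving a number 55 percentage points higher from compound 1 to compound 4 (beyond the scatter). The much smaller group also matches the larger group of compound 2, as the step of a number 9 percentage points lower from compound 2 to compound 4 (within the scatter) separates the two by no more than the usual scatter.

As far as these compounds go, whether the free amine or an ethyl group on this nitrogen would hold this level remains open. Nothing shown here accounts for the rise.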